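The compounds below may be only part of what the source reports. "The series", "measured", "known", "first", "only" and "open" are said of these compounds alone.

Measured compounds:
compound 1 `Cc1ccc(S(=O)(=O)N2C=CNC(=O)[C@H]2CC(=O)N[C@H]2CCN(C)CC2(C)C)cc1`: 0.42 nM
compound 2 `CCN1CC[C@H](NC(=O)C[C@@H]2C(=O)NC=CN2S(=O)(=O)c2ccc(C)cc2)C(C)(C)C1`: 0.63 nM
compound 3 `Cc1ccc(S(=O)(=O)N2C=CNC(=O)[C@H]2CC(=O)N[C@H]2CCN(Cc3ccccc3)CC2(C)C)cc1`: 1.09 nM

In an in vitro functional assay on cells for antagonist activity at B1 bradykinin receptor (Homo sapiens), read by luminescence and calcium flux, with a stated time of 2 h (a lower number here means a stronger inhibitor, a higher number a weaker inhibitor), compound 3 gives the highest of the three numbers shown. Its nearest neighbour is compound 2 and the gap is a 1.7-fold higher number from compound 2 to compound 3 (0.24 log units; within the scatter), which leaves no order to speak of between them; the wider gap is a 2.6-fold higher number from compound 1 to compound 3 (0.41 log units; beyond the scatter), a modest but real difference.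

Compound 4 `Cc1ccc(S(=O)(=O)N2C=CNC(=O)[C@H]2CC(=O)N[C@H]2CCN(C3CCCC3)CC2(C)C)cc1` differs from compound 3 in one place: cyclopentyl in place of benzyl on an amine nitrogen in a ring. The steps already seen all concern the same amine nitrogen in a ring. The change from compound 1 to compound 2 gave a 1.5-fold higher number from compound 1 to compound 2 (0.18 log units; within the scatter), from compound 2 to compound 3 a 1.7-fold higher number from compound 2 to compound 3 (0.24 log units; within the scatter), and from compound 1 to compound 3 a 2.6-fold higher number from compound 1 to compound 3 (0.41 log units; beyond the scatter). These are small steps with one modest movement, so a group of a size between the ones tried is expected to leave this assay little changed. For compound 4 the step expected is a 1.4-fold lower number from compound 3 to compound 4 (0.13 log units; within the scatter), not beyond the scatter. Compound 4 is estimated at 0.8 nM, within a range from 0.35 nM to 2 nM.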

Compound 4, half-maximal inhibitory concentration: 0.247 nM
The estimate for compound 4 lay 3.2-fold (0.51 log units) above the measured number; measured number outside the range, below it.
By their numbers in this assay, from the lowest: compounds 4, 1, 2 and 3 (each within the scatter of the next, the first and the last beyond it).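

In this assay the ring nitrogen carries a cycloalkyl group as well as it carries the small alkyl groups: cyclopentyl in place of methyl gives a 1.7-fold lower number from compound 1 to compound 4 (0.23 log units; within the scatter), so the two cannot be ordered. The earlier compounds shown here suggested that the number rises with the size of the group on this nitrogen, but compound 4 goes against that, since cyclopentyl in place of ethyl gives a 2.6-fold lower number from compound 2 to compound 4 (0.41 log units; beyond the scatter). Benzyl now stands apart from cyclopentyl, with a 4.4-fold lower number from compound 3 to compound 4 (0.64 log units; beyond the scatter), a larger movement than any step among compounds 1, 2 and 3.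

Nothing available explains this difference between the two groups. Going by these compounds, it remains open whether the difference follows the aromatic ring or the extra carbon of benzyl, and cyclohexyl or cyclopentylmethyl on the same nitrogen would separate the two.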